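Adding Fluoro to a Compound With Flat Configuration Steps

This account rests on a few compounds, and the source may have more. Where it says the series, first, only, none or still open, it means among the compounds named here.

Values in a functional assay on T98G cells (Homo sapiens) for cytotoxicity, read by MTT assay, with a stated time of 48 h; a lower number here means a stronger inhibitor, a higher number a weaker inhibitor:
- Compound 1 `C/C(=N/NC(=S)Nc1ccccc1)c1ccccn1`: 6.81 nM
- Compound 2 `CC(=NNC(=S)Nc1ccccc1)c1ccccn1`: 6.8 nM
- Compound 3 `C/C(=N\NC(=S)Nc1ccccc1)c1ccccn1`: 6.81 nM

Compound 1 stands level with compound 3 at the digits given and within the scatter of compound 2. The three measured steps are a 1.0-fold lower number from compound 1 to compound 2 (0.00 log units; within the scatter), no change at the digits printed from compound 1 to compound 3 (within the scatter) and a 1.0-fold higher number from compound 2 to compound 3 (0.00 log units; within the scatter). All lie within the scatter, and each concerns only how a double bond is drawn, as shown by the fact that one of compounds 1 and 2 is drawn with a defined configuration and the other without, at the place where they differ, the fact that compounds 1 and 3 differ only in the configuration as drawn and (the fact that one of compounds 2 and 3 is drawn with a defined configuration and the other without, at the place where they differ).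

Compound 4 `C/C(=N/NC(=S)Nc1cccc(F)c1)c1ccccn1` differs from compound 1 by fluoro in place of hydrogen on an aromatic carbon, which is fluoro in place of hydrogen on an aromatic carbon. Within the data shown here, no measured step touches that ring, so these steps bear on the change only indirectly and give no direction. The expectation therefore starts from compound 1 at 6.81 nM, with a wide margin. The estimated change is a 1.0-fold lower number from compound 1 to compound 4 (0.02 log units; within the scatter), and no shift beyond the scatter is expected. For compound 4 the expected value in this assay is 6.5 nM, within an estimated range of 2 nM to 20 nM.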

Compound 4, half-maximal inhibitory concentration: 12 nM
Compound 4: middle estimate off by 1.8-fold (0.27 log units), on the low side; low and high end bracket the measured number.
By their numbers in this assay, from the lowest: compounds 2, 1, 3 and 4 (each within the scatter of the next).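

In this assay, fluoro in place of hydrogen on an aromatic carbon, meta to a large group, gives a 1.8-fold higher number from compound 1 to compound 4 (0.25 log units; within the scatter). This is the first step shown that changes the atoms rather than how a double bond is drawn, and it shows that fluoro can stand at this place on the six-membered aromatic ring without a shift beyond the scatter. Nothing known about these compounds accounts for the size of this step.

As far as these compounds go, whether a larger group at the same place, such as chloro, methoxy or an amine, would move the number beyond the scatter remains open. Also open, from the compounds shown here alone, is whether the way the double bond is drawn would matter once fluoro is present.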